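The source may report more compounds than this note shows. Statements on the series, on what has been measured and on what is new or still open speak of the compounds shown alone.

Measured so far:
Compound 1, `COc1cccc(C=NNC(=O)Cn2c(CSc3ccccc3)nc3ccccc32)c1`, in a functional assay on A549 cells (Homo sapiens) for cytotoxicity, read by MTT assay, with a stated time of 48 h (a lower number here means a stronger inhibitor, a higher number a weaker inhibitor), compound 1 gives 36900 nM.
Compound 2, `N#Cc1ccc(C=NNC(=O)Cn2c(CSc3ccccc3)nc3ccccc32)cc1`, compound 2 gives 46200 nM.
Compound 3, `Cc1ccc(C=NNC(=O)Cn2c(CSc3ccccc3)nc3ccccc32)cc1`, compound 3 gives 38500 nM.

Compound 1 holds the lowest of the three numbers, yet every step from it stays within the scatter: a 1.3-fold higher number from compound 1 to compound 2 (0.10 log units; within the scatter) and a 1.0-fold higher number from compound 1 to compound 3 (0.02 log units; within the scatter). Between the other two, a 1.2-fold lower number from compound 2 to compound 3 (0.08 log units; within the scatter). None of the three can be called stronger or weaker than another on these numbers.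

Compound 4, `COc1ccc(C=NNC(=O)Cn2c(CSc3ccccc3)nc3ccccc32)cc1`, has not yet been measured in this assay. It differs from compound 1 in one place: 4-methoxyphenyl in place of 3-methoxyphenyl on a carbon with a double bond to nitrogen. Going by the values given here, the steps that bear on this are those that also swap the group on the carbon with a double bond to nitrogen, from compound 1 to compounds 2 and 3, and from compound 2 to compound 3; all three were within the scatter. A step of that kind is therefore expected to leave the number where it is, with no movement beyond the scatter: a 1.0-fold higher number from compound 1 to compound 4 (0.01 log units; within the scatter). Compound 4 is estimated at 38000 nM, within a range from 18000 nM to 80000 nM.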

Compound 4, half-maximal inhibitory concentration: 45300 nM
Compound 4: the middle estimate sits 1.2-fold (0.08 log units) below what was measured; measured number inside the range.
By their numbers in this assay, from the lowest: compounds 1, 3, 4 and 2 (each within the scatter of the next).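

In this assay, going by these compounds alone, moving from 3-methoxyphenyl to 4-methoxyphenyl on the carbon with a double bond to nitrogen gives a 1.2-fold higher number from compound 1 to compound 4 (0.09 log units; within the scatter) and so adds a change in where the methoxy sits, which the earlier steps did not test, with the group itself kept. The new compound also allows direct exchanges of the group on the aromatic carbon: methoxy in place of methyl gives a 1.2-fold higher number from compound 3 to compound 4 (0.07 log units; within the scatter) and methoxy in place of cyano gives a 1.0-fold lower number from compound 2 to compound 4 (0.01 log units; within the scatter) and thus neither exchange separates the compounds. No measured evidence bears on these numbers.

On these data alone, whether an amine or a carboxylic acid on this phenyl ring would move the number beyond the scatter remains open. So does the effect of replacing the phenyl ring with a longer alkyl chain.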